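Swapping the aryl end of a quinoline urea for a hydroxyalkyl chain

The compounds below may be only part of what the source reports. "The series", "measured", "known", "first", "only" and "open" are said of these compounds alone.

Compound 2 `COc1cc(NC(C)CCCNC(=O)Nc2ccc(Cl)c(C(F)(F)F)c2)c2ncccc2c1` is the strongest of the two numbered compounds in a functional assay on HeLa cells (Homo sapiens) for inhibition, read by MTT assay, with a stated time of 4 days (a lower number here means a stronger inhibitor, a higher number a weaker inhibitor), where compound 2 gives 3900 nM. Compound 3 `COc1ccc(/C(=N/NC(=O)NCCCC(C)Nc2cc(OC)cc3cccnc23)c2ccccc2)cc1` gives 129000 nM, a gap beyond the scatter. Compound 1 `CCOC(=O)NC(c1ccccc1)c1ccc(Cl)cc1` reaches only a limit of the assay, > 250000 nM, which is the limit of > 250000 nM in this assay, at which 1 of the 3 values shown sits. The untested compound 4 `COc1cc(NC(C)CCCNC(=O)NNC(=O)NCCCCCO)c2ncccc2c1` differs from compound 2 by ((5-hydroxypentyl)carbamoyl)amino in place of 4-chloro-3-(trifluoromethyl)phenyl on an amide-type nitrogen. Compound 3 shows that a bulky change at the urea end costs much potency, so a step in the same weakening direction is expected, with compound 4 estimated at 40000 nM (range 10000 nM to 200000 nM). This means an expected step of a 10-fold higher number from compound 2 to compound 4 (1.01 log units; beyond the scatter) in this assay.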

Compound 4, half-maximal inhibitory concentration: >= 250000 nM
Compound 4: only a limit was reported; the forecaster's own chance of this, stated with the estimate: 20%; middle value at least 6.2-fold (0.79 log units) from the limit.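

Within the data shown here, putting ((5-hydroxypentyl)carbamoyl)amino in place of 4-chloro-3-(trifluoromethyl)phenyl on this amide-type nitrogen gives the first single-place comparison in this assay, an at least 64-fold higher number from compound 2 to compound 4 (1.80 log units; beyond the scatter). On these data alone, compound 4 gives only a limit of the assay, so the full size of this loss stays unknown: the limit of >= 250000 nM in this assay, at which 1 of the 4 values shown sits. At this position, then, the ring-free chain does not keep the activity of the chlorinated aromatic ring.

This one change removes the ring and adds the chain together, leaving open which of the two matters. A plain pyridine ring, or a chain ending in an amine, at this place would help separate them.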